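The compounds below may be only part of what the source reports. "The series", "measured", "known", "first", "only" and "open" are said of these compounds alone.

Measured so far in a physicochemical assay for lipophilicity, at pH 7.4; on this read-out lower numbers stand for lower lipophilicity and higher numbers for higher lipophilicity:

- Compound 1 `CCn1nc(CC(=O)Nc2ccc(OC(F)(F)F)c(Cl)c2)c2ccccc2c1=O` gives 5.42
- Compound 2 `O=C(O)Cn1nc(Cc2nc3cc(Cl)c(OCC(F)F)cc3[nH]2)c2ccccc2c1=O` gives 1.97

Compound 2 holds the lower of these two numbers, and compound 1 lies above it by a gap beyond the usual scatter of repeat measurements. Compound 3 `CCOc1cc2[nH]c(Cc3nn(CC(=O)O)c(=O)c4ccccc34)nc2cc1Cl` is still unmeasured. Its difference from compound 2 is methyl in place of difluoromethyl on a saturated chain carbon bound to an oxygen on an aromatic ring and amounts to methyl in place of difluoromethyl on a saturated chain carbon bound to an oxygen on an aromatic ring. Among the compounds with values here, the two measured compounds do not differ in just one place, so no measured step guides this judgement. The expectation in this assay is no step beyond the scatter. In numbers, the estimated move is a number 0.07 log units lower from compound 2 to compound 3 (within the scatter) and nothing larger is expected. For compound 3 the estimated value is 1.9 (range 1.55 to 2.25).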

Compound 3, distribution coefficient: 1.8
Beside the measured number, compound 3's estimate is 0.10 log units above it; the measured number falls inside the stated range.
By their numbers in this assay, from the lowest: compounds 3 and 2 (each within the scatter of the next); then compound 1.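

In this assay, within the data shown here, the swap of difluoromethyl for methyl on a saturated chain carbon bound to an oxygen on an aromatic ring gives a number 0.17 log units lower from compound 2 to compound 3 (within the scatter) and is the first single-place comparison here. At this position, 2,2-difluoroethoxy and ethoxy therefore cannot be told apart in this read-out, though this rests on one pair of compounds on one shared core. No measurement shown explains this result. Still open, going by these compounds, is whether a longer chain, such as propyl, or an amine at this place would give a step beyond the scatter.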